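The compounds below may be only part of what the source reports. "The series", "measured", "known", "first", "only" and "open" are said of these compounds alone.

Measured in a functional assay on A549 cells (Homo sapiens) for cytotoxicity, read by sulforhodamine B assay; a higher number here means a weaker inhibitor, a lower number a stronger inhibitor:
Compound 1 `COCOc1ccccc1-c1cc2ccccc2c(=O)[nH]1`: 23600 nM
Compound 2 `COCOc1ccccc1-c1cc2cc(C)ccc2c(=O)[nH]1`: > 100000 nM, a limit
Compound 3 `COCOc1ccccc1-c1cc2ccccc2c(=O)n1C`: > 100000 nM, a limit

Compound 3 therefore stands without a number, at a limit of the assay. Compound 4 `COCOc1ccccc1-c1cc2cc(C)ccc2c(=O)n1C` differs from it by one change, methyl in place of hydrogen on an aromatic carbon. The same change on compound 1 gave an at least 4.2-fold higher number from compound 1 to compound 2 (0.62 log units; beyond the scatter), beyond the scatter. Methyl on the aromatic nitrogen gave an at least 4.2-fold higher number from compound 1 to compound 3 (0.62 log units; beyond the scatter), also beyond the scatter. As far as these compounds go, both steps end at the limit of > 100000 nM in this assay, at which 2 of the 3 values shown sit, so their true sizes are unknown. Both point to a higher number, and compound 3 has already reached the limit. What is expected is a step that the limit leaves unreadable from compound 3 to compound 4, probably reported only as a limit. For compound 4 the estimated value is 150000 nM, with an expected range from 60000 nM to 400000 nM.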

Compound 4, half-maximal inhibitory concentration: 99800 nM
For compound 4 the middle estimate is 1.5-fold (0.18 log units) above the measured one; the range from low to high includes it.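

In this assay, methyl on the aromatic carbon gives a number no higher from compound 3 to compound 4 (the limit leaves the size open), and it does not act alike on the two cores: the same change on two cores in this assay, an at least 4.2-fold higher number (0.62 log units; beyond the scatter) from compound 1 to compound 2 and a number no higher (the limit leaves the size open) from compound 3 to compound 4, at least 4.2-fold (0.62 log units) apart, beyond the scatter of two such steps. Methyl on the aromatic nitrogen gives a number no higher from compound 2 to compound 4 (the limit leaves the size open), and it shows the same split: the same change on two cores in this assay, an at least 4.2-fold higher number (0.62 log units; beyond the scatter) from compound 1 to compound 3 and a number no higher (the limit leaves the size open) from compound 2 to compound 4, at least 4.2-fold (0.62 log units) apart, beyond the scatter of two such steps. The sizes of both steps into compound 4 cannot be read, but the doubly methylated compound 4 still carries a measured number rather than a limit. The compounds shown leave open how an amine or a carboxylic acid at this aromatic carbon, or a longer chain on the aromatic nitrogen, would read in this assay.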